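This account rests on a few compounds, and the source may have more. Where it says the series, first, only, none or still open, it means among the compounds named here.

In a functional assay on IGROV-1 cells (Homo sapiens) for inhibition (a higher number here means a weaker inhibitor of growth, a lower number a stronger inhibitor of growth), compound 1 (`Nc1ccc(-c2nc3cc(F)ccc3s2)cc1`) gives 11500 nM. This is the highest of the three numbers and makes it the weakest growth inhibitor so far, with compound 3 (`Cc1cc(-c2nc3ccc(F)cc3s2)ccc1N`) at 1300 nM and compound 2 (`Cc1cc(-c2nc3cccc(F)c3s2)ccc1N`) at 70 nM. Compound 4 (`Nc1ccc(-c2nc3cc(F)ccc3s2)cc1Br`) places bromo in place of hydrogen on an aromatic carbon, ortho to an amino group and meta to a large group: bromo in place of hydrogen on an aromatic carbon. Going by the values given here, no measured pair shows this change on its own, so any forecast is loose. With compound 1 at the top of the range, a clear move to a lower number is expected, beyond the scatter. The expected step is a 19-fold lower number from compound 1 to compound 4 (1.28 log units; beyond the scatter). For compound 4 the estimated value is 600 nM, with an expected range from 60 nM to 6000 nM.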

Compound 4, concentration for 50% growth inhibition: < 10 nM
Compound 4 ended at the assay's limit; the forecaster's own chance of this, stated with the estimate: 3%; middle value at least 60-fold (1.77 log units) from the limit.
By their numbers in this assay, from the lowest: compound 2; then compound 3; then compound 1. At a limit, below all of these: compound 4.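

Bromo in place of hydrogen on an aromatic carbon, ortho to an amino group, gives an at least 1100-fold lower number from compound 1 to compound 4 (3.06 log units; beyond the scatter) in this assay, the first single-change step in this set. Compound 4 reads < 10 nM, which is a limit of the assay and not a number. This one position therefore responds very strongly to a single added atom, but the full size of the step remains unknown: the limit of < 10 nM in this assay, at which 1 of the 4 values shown sits.

Going by these compounds, whether chloro or a nitrile at the same position would give a similar step remains open. So does whether bromo would have the same effect with the fluoro group elsewhere on the core.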